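Carbonyl substituent change in an adenosine A2b binding series

A few compounds are considered here, and "the series" means these few. Any claim that something is new, unique, unknown or untested is made for them only; others in the source may bear on it.

Measured so far:
compound 1 `CC1=C(C(=O)C2CC2)C(c2ccoc2)NC(=O)N1` — 10%
compound 2 `CCN(CC)C(=O)C1=C(C)NC(=O)NC1c1ccoc1` — 12%

In an assay on membranes from HEK293 cells for displacement of a labelled ligand from adenosine receptor A2b (Homo sapiens), read by scintillation counting, with a stated time of 30 min, tested at 1 uM (on this read-out higher numbers stand for more inhibition at the one concentration tested (going by the name of the read-out) and lower numbers for less inhibition), compound 1 gives 10% and compound 2 gives 12%. Compound 2 cannot be told apart from compound 1 on these numbers, since a number 2 percentage points higher from compound 1 to compound 2 (within the scatter) falls within the scatter. Compound 3 `CCC(CC)OC(=O)C1=C(C)NC(=O)NC1c1ccoc1` carries (pentan-3-yl)oxy in place of diethylamino on a carbonyl carbon. Among the compounds with values here, the only step that bears on this change is the one from compound 1 to compound 2, and it was small. In this assay no shift beyond the scatter is therefore expected for compound 3, with no change at the digits printed from compound 2 to compound 3 (within the scatter) as the estimated step. Compound 3 is expected to give 12%, in the range 0% to 30%.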

Compound 3, a percentage reported as inhibition, at one concentration (the size of the read-out at that concentration, not a potency): 28%
The estimate for compound 3 lay 16 percentage points below the measured number; the range from low to high includes it.
By their numbers in this assay, from the lowest: compounds 1 and 2 (each within the scatter of the next); then compound 3.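

On this carbonyl carbon the substituent can move the reading in this assay: (pentan-3-yl)oxy in place of diethylamino gives a number 16 percentage points higher from compound 2 to compound 3 (beyond the scatter), a shift beyond the scatter that the earlier cyclopropyl-to-diethylamino step did not show. Against cyclopropyl, the same group gives a number 18 percentage points higher from compound 1 to compound 3 (beyond the scatter), which places compound 3 clear of both other compounds. No data here explain this difference.

The compounds shown do not separate the effect of the oxygen link from that of the branched pentan-3-yl chain. Methoxy or (pentan-3-yl)amino at this carbonyl carbon would bear on that question.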